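Trading a Methyl for a Nitro on the Benzoyl Ring

The compounds below may be only part of what the source reports. "The series", "measured", "known", "first", "only" and "open" are said of these compounds alone.

Measured compounds:
compound 1 `COc1cc(-c2nnc3n2NC(c2ccco2)C(C(=O)c2ccc(Br)cc2)S3)cc(OC)c1OC` — 36400 nM
compound 2 `COc1cc(-c2nnc3n2NC(c2cccs2)C(C(=O)c2ccc(C)cc2)S3)cc(OC)c1OC` — 5090 nM
compound 3 `COc1cc(-c2nnc3n2NC(c2ccco2)C(C(=O)c2ccc(C)cc2)S3)cc(OC)c1OC` — 7500 nM

In a functional assay on PC-3 cells (Homo sapiens) for cytotoxicity, read by MTT assay, with a stated time of 48 h (a lower number here means a stronger inhibitor, a higher number a weaker inhibitor), compound 3 gives 7500 nM, the second highest of the three numbers. Its nearest neighbour is compound 2, and the two differ only by furan-2-yl in place of thiophen-2-yl on a saturated ring carbon: a 1.5-fold higher number from compound 2 to compound 3 (0.17 log units; within the scatter). The furthest is compound 1, which carries bromo where compound 3 carries methyl: a 4.9-fold lower number from compound 1 to compound 3 (0.69 log units; beyond the scatter).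

Compound 4 `COc1cc(-c2nnc3n2NC(c2ccco2)C(C(=O)c2ccc([N+](=O)[O-])cc2)S3)cc(OC)c1OC` is the next step from compound 3: nitro in place of methyl on an aromatic carbon. Among the measured compounds shown here, only one measured step touches this same aromatic carbon, and it is the one from compound 1, where a change of the group there moved the number beyond the scatter, as a 4.9-fold lower number from compound 1 to compound 3 (0.69 log units; beyond the scatter) shows. For the measured compounds named here, no measured compound carries nitro, so the direction for nitro rests on that single step alone. Since methyl was the better of the two groups seen at this position, exchanging it for another group is expected to raise the number modestly rather than lower it; the expected step is a 1.7-fold higher number from compound 3 to compound 4 (0.24 log units; within the scatter).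

Compound 4 is therefore estimated at 13000 nM, with a range from 4000 nM to 40000 nM.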

Compound 4, half-maximal inhibitory concentration: 27900 nM
The estimate for compound 4 lay 2.1-fold (0.33 log units) below the measured number, within the range that was stated.
By their numbers in this assay, from the lowest: compounds 2 and 3 (each within the scatter of the next); then compounds 4 and 1 (each within the scatter of the next).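

In this assay, the step of a 3.7-fold higher number from compound 3 to compound 4 (0.57 log units; beyond the scatter) is a second change at this aromatic carbon that moves the number beyond the scatter, and again the higher number belongs to the group that is not methyl. The new step, a 1.3-fold lower number from compound 1 to compound 4 (0.12 log units; within the scatter), lies within the scatter, so nitro and bromo cannot be told apart here even though they differ in atoms and in hydrogen-bond acceptors, and methyl stands apart from both in this furan-2-yl series. No measurement at hand explains why the methyl compound separates from the other two.

With only three groups seen at this position, the compounds shown leave open where an amine, a methoxy group or a carboxylic acid on this aromatic carbon would fall, and so whether methyl is unusual or nitro and bromo are. Nitro and bromo also appear only alongside furan-2-yl on the saturated ring carbon, so it remains open whether the same separation from methyl would hold with thiophen-2-yl there.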